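The source may report more compounds than this note shows. Statements on the series, on what has been measured and on what is new or still open speak of the compounds shown alone.

Working notes on the series. Of the compounds shown here, two have measured values so far: compound 1 (`Cc1ccc(CS/C(=C/c2ccc(O)cc2)C(=O)c2ccc(Cl)cc2)cc1`) and compound 2 (`Cc1cc(C)cc(/C=C(\C(=O)c2ccc(Br)cc2)S(=O)(=O)Cc2ccc(F)cc2)c1`). In a functional assay on DU-145 cells (Homo sapiens) for inhibition, read by trypan blue exclusion, with a stated time of 96 h (on this read-out higher numbers stand for weaker inhibition of growth and lower numbers for stronger inhibition of growth), compound 1 gives 10000 nM and compound 2 gives 10000 nM as well, so compound 2 stands level with compound 1, within the scatter. For the measured compounds named here, no two measured compounds differ in one place only, so the series offers no measured step to carry over.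

The next structure is compound 3 (`COc1ccc(/C=C(\C(=O)c2ccc(Br)cc2)S(=O)(=O)Cc2ccc(F)cc2)cc1`), which is derived from compound 2 by a single change (4-methoxyphenyl in place of 3,5-dimethylphenyl on a double-bonded chain carbon bound to a double-bonded chain carbon): 4-methoxyphenyl in place of 3,5-dimethylphenyl on a double-bonded chain carbon bound to a double-bonded chain carbon. The rest of the structure stays the same.

With so little to go on, the expectation is weak. A small shift toward stronger inhibition of growth is expected, and it may not clear the scatter. The expected step in this assay is (a 2.0-fold lower number from compound 2 to compound 3 (0.30 log units; within the scatter)). Compound 3 is estimated at 5000 nM (1000 nM to 12000 nM).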

Compound 3, concentration for 50% growth inhibition: 25000 nM
Compound 3: middle estimate off by 5.0-fold (0.70 log units), on the low side; the whole stated range lies below it.
By their numbers in this assay, from the lowest: compounds 1 and 2 (each within the scatter of the next); then compound 3.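

In this assay, 4-methoxyphenyl in place of 3,5-dimethylphenyl on a double-bonded chain carbon bound to a double-bonded chain carbon gives a 2.5-fold higher number from compound 2 to compound 3 (0.40 log units; beyond the scatter), so this position responds to substitution, with a modest move toward weaker inhibition of growth while the rest of the structure stays the same. This single swap changes several things at once: the two methyl groups leave, a methoxy group enters at a different ring position, and the entering group holds an oxygen and a hydrogen-bond acceptor, so the step cannot be assigned to any one of these features. No measurement shown here bears on the reason for the step.

The compounds shown leave open whether a 4-methylphenyl group, which would separate ring position from the oxygen, would stay level with compound 2 or follow compound 3. They also leave open whether an amine or a carboxylic acid on this ring would give a lower number than either compound, and how much of the series' behaviour depends on the other parts of the core.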